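Replacing the Sulfur Link with a Dialkylamine

The source may hold more compounds than are shown below. What is called first, only, known or untested is meant among the compounds shown, and "the series" means these compounds.

Compound 2 `CCc1nc(-c2ccc(Cl)cc2Cl)c(CC)nc1SC(C)CC` carries a (sec-butyl)sulfanyl group on the shared core. In an assay on IMR-32 cells for displacement of a labelled ligand from corticotropin-releasing factor receptor 1 (Homo sapiens), read by scintillation counting, with a stated time of 2 h (a higher number here means a weaker inhibitor, a lower number a stronger inhibitor), compound 2 gives 401 nM, the highest of the three numbers and therefore the weakest binder of this set. Compound 1 `CCC(CC)Nc1nc(OC)c(-c2ccc(Cl)cc2Cl)nc1C` gives 14.4 nM and compound 3 `CCc1nc(-c2cnc(OC)nc2OC)c(CC)nc1NC(CC)CC` gives 17.2 nM; each attaches its side chain through nitrogen rather than sulfur, and each stands beyond the scatter from compound 2. Compound 4 `CCc1nc(N(CC2CC2)CC2CC2)c(CC)nc1-c1ccc(Cl)cc1Cl` makes the change (bis(cyclopropylmethyl)amino in place of (sec-butyl)sulfanyl on an aromatic carbon). A large step toward a lower number is expected, a 20-fold lower number from compound 2 to compound 4 (1.30 log units; beyond the scatter), because compound 1 gives 14.4 nM and compound 3 gives 17.2 nM with nitrogen-linked chains. Compound 4 is therefore estimated at 20 nM, with a likely range from 5 nM to 100 nM.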

Compound 4, inhibition constant: 26 nM
Estimate against measurement, compound 4: 1.3-fold (0.11 log units) below, and the stated range covers the measured number.
By their numbers in this assay, from the lowest: compounds 1, 3 and 4 (each within the scatter of the next); then compound 2.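

Bis(cyclopropylmethyl)amino in place of (sec-butyl)sulfanyl gives a 15-fold lower number from compound 2 to compound 4 (1.19 log units; beyond the scatter) on the shared core, the first comparison in this set that changes only one place. Compounds 1 and 3 each differ from compound 2 in more than one place, so this pair alone ties a large step to this position. The data offer no measured explanation for the step.

From the compounds shown here alone, this change replaces both the linking atom and the side chain, so the share of each stays open. A (sec-butyl)amino group at this position, which would change the link alone, could separate the two.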